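Notes on a pentafluoroethyl exchange in the series

A few compounds are considered here, and "the series" means these few. Any claim that something is new, unique, unknown or untested is made for them only; others in the source may bear on it.

Compound 1 `CC(O)(COc1cccc(S(F)(F)(F)(F)F)c1)C(=O)Nc1ccc(C(F)(F)F)cc1` gives 23800 nM in a functional assay on VCaP cells (Homo sapiens) for antiproliferative activity, read by propidium iodide staining, with a stated time of 96 h; a higher number here means a weaker inhibitor, a lower number a stronger inhibitor. Compound 3 `CC(O)(COc1cccc(C(F)(F)C(F)(F)F)c1)C(=O)Nc1ccc(C(F)(F)F)cc1` differs from it by a group of 7 heavy atoms (2 carbon, 5 fluorine; no ring) in place of a group of 6 heavy atoms (5 fluorine, 1 sulfur; no ring), on an aromatic carbon; in this assay compound 3 gives 8100 nM, a step of a 2.9-fold lower number from compound 1 to compound 3 (0.47 log units; beyond the scatter). Compound 2 `CC(O)(COc1ccc(S(F)(F)(F)(F)F)cc1)C(=O)Nc1cc(C(F)(F)F)cc(C(F)(F)F)c1` gives 2400 nM in this assay, the lowest of the three numbers; the difference between the core of compound 2 and the core of compound 1 is not broken down here. Compound 4 `CC(O)(COc1ccc(C(F)(F)C(F)(F)F)cc1)C(=O)Nc1cc(C(F)(F)F)cc(C(F)(F)F)c1` has not yet been measured. It differs from compound 2 by a group of 7 heavy atoms (2 carbon, 5 fluorine; no ring) in place of a group of 6 heavy atoms (5 fluorine, 1 sulfur; no ring), on an aromatic carbon, the same kind of change as from compound 1 to compound 3, though the place is not identical: in compound 1 the group sits meta to a large group, in compound 2 para to a large group. Going by the values given here, the single measured step of this kind is the only footing. From compound 2 to compound 4 a step of about a 2.7-fold lower number from compound 2 to compound 4 (0.43 log units; beyond the scatter) is expected in this assay, because the same kind of change gave a 2.9-fold lower number from compound 1 to compound 3 (0.47 log units; beyond the scatter); the changed place and the unknown carry-over between cores widen the range. Compound 4 is estimated at 900 nM, from 350 nM to 2600 nM.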

Compound 4, half-maximal inhibitory concentration: 3000 nM
Compound 4: middle estimate off by 3.3-fold (0.52 log units), on the low side; measured number above the stated range.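

In this assay, replacing the group of five fluorines and one sulfur with 1,1,2,2,2-pentafluoroethyl on the core of compound 2 gives a 1.3-fold higher number from compound 2 to compound 4 (0.10 log units; within the scatter), a step that stays within the scatter. The lower number seen on the core of compound 1 did not carry over, so the same exchange cannot be assumed to give the same result across these two cores: the same change on two cores in this assay, a 2.9-fold lower number (0.47 log units; beyond the scatter) from compound 1 to compound 3 and a 1.3-fold higher number (0.10 log units; within the scatter) from compound 2 to compound 4, 3.7-fold (0.57 log units) apart, beyond the scatter of two such steps

Going by these compounds alone, this does not show what separates the two results, since the exchange sits in a different place in each pair and the cores also differ elsewhere, and only one pair per core is at hand.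

The compounds shown leave open whether the step depends on the place of the exchanged group or on the rest of the core, as neither can be varied alone here. Also open, as far as these compounds go, is how a nitrile or a longer perfluoroalkyl chain would read at the same place on the core of compound 2.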